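A few compounds are considered here, and "the series" means these few. Any claim that something is new, unique, unknown or untested is made for them only; others in the source may bear on it.

Measured compounds:
- compound 1, `C[C@@H](O)[C@H]1C(=O)N2C(C(=O)OCOC(=O)OC3Cc4ccccc4C3)=C(S[C@@H]3CN[C@H](C(=O)N(C)C)C3)[C@H](C)[C@H]12`, 0.217 h
- compound 2, `C[C@@H](O)[C@H]1C(=O)N2C(C(=O)OCOC(=O)OC3CCCc4ccccc4C3)=C(S[C@@H]3CN[C@H](C(=O)N(C)C)C3)[C@H](C)[C@H]12`, 0.35 h
- compound 3, `C[C@@H](O)[C@H]1C(=O)N2C(C(=O)OCOC(=O)O[C@H]3CCCCc4ccccc43)=C(S[C@@H]3CN[C@H](C(=O)N(C)C)C3)[C@H](C)[C@H]12`, 0.155 h

In a physicochemical assay for metabolic stability, read by HPLC, in simulated gastric fluid, at pH 1.2, tested at 100 uM (on this read-out lower numbers stand for a shorter-lived compound and higher numbers for a longer-lived compound), compound 3 gives the lowest of the three numbers. Its nearest neighbour is compound 1, with a 1.4-fold lower number from compound 1 to compound 3 (0.15 log units; within the scatter); the gap to compound 2 is wider, a 2.3-fold lower number from compound 2 to compound 3 (0.35 log units; beyond the scatter), and compound 1 and compound 2 sit within the scatter of each other, a 1.6-fold higher number from compound 1 to compound 2 (0.21 log units; within the scatter).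

Compound 4, `C[C@@H](O)[C@H]1C(=O)N2C(C(=O)OCOC(=O)O[C@@H]3CCCCc4ccccc43)=C(S[C@@H]3CN[C@H](C(=O)N(C)C)C3)[C@H](C)[C@H]12`, is the unmeasured partner of compound 3. The change is the two compounds have the same atoms and bonds and differ only in configuration as drawn: 1 of 7 stereo elements differ; a stereocentre at a saturated ring carbon is drawn S in compound 3 and R in compound 4; the carbonate carrier itself is otherwise unchanged, as is the shared core.

None of the three measured steps bears directly on this change: all of them swap one carrier group for another, whereas here the atoms and bonds are identical and only the configuration at the saturated ring carbon is drawn differently. The measured steps themselves are small, two within the scatter and one only modest, which gives no basis for expecting a stereochemical inversion alone to move this assay far. The expected step is therefore a 1.1-fold higher number from compound 3 to compound 4 (0.04 log units; within the scatter), in no particular direction beyond the scatter. Compound 4 is estimated at 0.17 h in this assay, within 0.085 h to 0.34 h.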

Compound 4, half-life: 0.183 h
For compound 4 the middle estimate is 1.1-fold (0.03 log units) below the measured one; the range from low to high includes it.
By their numbers in this assay, from the lowest: compounds 3, 4, 1 and 2 (each within the scatter of the next, the first and the last beyond it).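

In this assay, turning the stereocentre at the saturated ring carbon from S to R gives a 1.2-fold higher number from compound 3 to compound 4 (0.07 log units; within the scatter), so this inversion, the only change of configuration alone among the compounds shown, does not separate the pair. The carrier of compound 4 also stays close to the other two carriers, with a 1.2-fold lower number from compound 1 to compound 4 (0.07 log units; within the scatter) and a 1.9-fold lower number from compound 2 to compound 4 (0.28 log units; within the scatter), whereas the earlier comparison with compound 3 gave a 2.3-fold lower number from compound 2 to compound 3 (0.35 log units; beyond the scatter), so the one gap beyond the scatter does not carry over to the other configuration and should not be read as a firm difference between carriers. This pair isolates configuration from every other structural variable: the fact that compounds 3 and 4 differ only in the configuration as drawn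

On these data alone, whether configuration stays this unimportant at the same position when the aromatic ring carries a substituent such as an amine or a carboxylic acid remains open, as does its effect in a carrier built on a longer open chain rather than a fused ring. The compounds shown also leave open whether the same pair stays this close anywhere outside this assay, for example in a medium at a different pH.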